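This account rests on a few compounds, and the source may have more. Where it says the series, first, only, none or still open, it means among the compounds named here.

Measured compounds:
Compound 1, `Cc1ccc(S(=O)(=O)Nc2ccc3oc(-c4ccccc4)nc3c2)cc1`: in an assay on cells for inhibition of HSP60/HSP10 (Homo sapiens), with a stated time of 60 min (on this read-out higher numbers stand for weaker inhibition and lower numbers for stronger inhibition), compound 1 gives > 100000 nM, which is a limit of the assay and not a number.
Compound 2, `O=S(=O)(Nc1ccc(-c2nc3ccccc3o2)cc1)c1cccc(O)c1`: in this assay compound 2 gives 62000 nM.
Compound 3, `O=S(=O)(Nc1ccc(-c2nc3ccccc3o2)cc1)c1ccc(O)cc1`: in this assay compound 3 gives 78000 nM.

For compound 1 the data hold only (the limit of > 100000 nM in this assay, at which 1 of the 3 values shown sits), so it cannot be placed against compound 2 or compound 3 by a number. The unmeasured compound 4, `O=S(=O)(Nc1ccc2oc(-c3ccccc3)nc2c1)c1ccc(Cl)s1`, shares its core with compound 1 and differs from it in one place: 5-chlorothiophen-2-yl in place of 4-methylphenyl on a sulfonyl sulfur. For the measured compounds named here, the one measured step, a 1.3-fold higher number from compound 2 to compound 3 (0.10 log units; within the scatter), concerns a hydroxyl moving on a phenyl ring in a differently arranged pair of compounds and does not touch a thiophene or a chlorine, so it gives no guide to the size or direction of the change from compound 1 to compound 4. With the starting point being a limit, no step beyond the scatter can be read off, and the expected step is a number no higher from compound 1 to compound 4 (the limit leaves the size open). Compound 4 is therefore estimated at 100000 nM, with a range from 30000 nM to 300000 nM, and a limit reading is again quite likely.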

Compound 4, half-maximal inhibitory concentration: 70000 nM
Estimate against measurement, compound 4: 1.4-fold (0.15 log units) above; the measured number falls inside the stated range.
By their numbers in this assay, from the lowest: compounds 2, 4 and 3 (each within the scatter of the next). At a limit, above all of these: compound 1.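

Placed on a sulfonyl sulfur whose other neighbour is the sulfonamide nitrogen, 5-chlorothiophen-2-yl gives the shared core a measured number in this assay, whereas 4-methylphenyl gave only a limit. This is an at least 1.4-fold lower number from compound 1 to compound 4 (0.15 log units; that floor lies within the scatter). So a five-membered aromatic ring with 1 hetero atom can replace a six-membered aromatic ring of carbon only at this position without a higher number, but the true size of the step stays open because the value for compound 1 is a limit of the assay and not a number: the limit of > 100000 nM in this assay, at which 1 of the 4 values shown sits.

The compounds shown do not separate the effect of the thiophene ring from that of its chlorine. They also leave open what an amine, a carboxylic acid or a longer alkyl chain would give on the sulfonyl sulfur.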